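The compounds below may be only part of what the source reports. "The series", "measured", "known", "first", "only" and "open" are said of these compounds alone.

Compound 1 `CCCOc1ccc([C@@H]2CC(=O)c3cc(CC=C(C)C)c(OC)cc3O2)cc1`: 63%
Compound 2 `COc1cc2c(cc1CC=C(C)C)C(=O)C[C@@H](c1ccc(Oc3ccc(F)cc3)cc1)O2`: 29%
Compound 3 `CCCCOc1ccc([C@@H]2CC(=O)c3cc(CC=C(C)C)c(OC)cc3O2)cc1`: 60%

These values come from a functional assay on HCT-116 cells (Homo sapiens) for inhibition, read by sulforhodamine B assay, with a stated time of 48 h, tested at 50 uM; a lower number here means less inhibition of growth, a higher number more inhibition of growth at the concentration tested. Compound 3 stands level with compound 1, with a number 3 percentage points lower from compound 1 to compound 3 (within the scatter). Compound 2 is set clearly apart, with a number 31 percentage points higher from compound 2 to compound 3 (beyond the scatter).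

The next compound to be tested is compound 4 `CCOc1ccc([C@@H]2CC(=O)c3cc(CC=C(C)C)c(OC)cc3O2)cc1`. Its difference from compound 3 is hydrogen in place of ethyl on a saturated chain carbon, two bonds along the chain from an oxygen on an aromatic ring. Put simply, butoxy becomes ethoxy, so the chain on the oxygen gets shorter.

Among the measured compounds shown here, the closest precedent is the change from propyl to butyl, with a number 3 percentage points lower from compound 1 to compound 3 (within the scatter), which is also a change in chain length. Swapping the propyl chain for 4-fluorophenyl is a different kind of change, and it gave a large drop, with a number 34 percentage points lower from compound 1 to compound 2 (beyond the scatter). It therefore says little about a simple trim. No chain shorter than propyl has been measured, so this is an extrapolation, and no shift beyond the scatter is expected in this assay.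

The expected change is no change at the digits printed from compound 3 to compound 4 (within the scatter). For compound 4 the estimated value is 60%, with an expected range from 47% to 72%.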

Compound 4, percent growth inhibition at one concentration: 65%
Compound 4: middle estimate off by 5 percentage points, on the low side, within the range that was stated.
By their numbers in this assay, from the lowest: compound 2; then compounds 3, 1 and 4 (each within the scatter of the next).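

Ethyl on this oxygen stands level with both longer chains in this assay: butyl to ethyl gives a number 5 percentage points higher from compound 3 to compound 4 (within the scatter) and propyl to ethyl gives a number 2 percentage points higher from compound 1 to compound 4 (within the scatter), so ethyl, propyl and butyl cannot be told apart here. The 4-fluorophenyl group remains clearly set apart, now from the ethyl compound as well, with a number 36 percentage points higher from compound 2 to compound 4 (beyond the scatter) as the step between them. No measurement among the data shown accounts for either the level values across these chains or the gap to 4-fluorophenyl.

From the compounds shown here alone, it remains open whether methyl, a longer hexyl chain or a chain ending in an amine would stay level with these compounds, and whether a plain phenyl would behave like 4-fluorophenyl. Readings at a single concentration also leave open whether the level compounds would separate at lower concentrations.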